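Para-Substituent Swap on a Nitroimidazooxazine Triazole Series

The compounds below may be only part of what the source reports. "The series", "measured", "known", "first", "only" and "open" are said of these compounds alone.

The shared core of compound 1 `O=[N+]([O-])c1cn2c(n1)OC[C@@H](OCc1cnn(-c3ccccc3)n1)C2` carries a phenyl-bearing triazole. In an ADME assay on Vero cells (Chlorocebus sabaeus) for cytotoxicity, with a stated time of 72 h (a lower number here means a stronger inhibitor, a higher number a weaker inhibitor), compound 1 gives only a limit of the assay, > 128000 nM. Compound 2 `O=[N+]([O-])c1cn2c(n1)OC[C@@H](OCc1cnn(-c3ccc(F)cc3)n1)C2` adds a fluoro to that ring; in this assay compound 2 likewise gives only a limit, > 128000 nM. The step that the two limits leave unreadable from compound 1 to compound 2 cannot be read, because both values rest on (the limit of > 128000 nM in this assay, at which 2 of the 2 values shown sit). Compound 3 `O=[N+]([O-])c1cn2c(n1)OC[C@@H](OCc1cnn(-c3ccc(OC(F)(F)F)cc3)n1)C2` is the next member, not yet measured, and it differs from compound 2 by trifluoromethoxy in place of fluoro on an aromatic carbon. For the measured compounds named here, the one measured step offers no direction, so no change beyond the scatter is expected in this assay: the estimated step is a step that the limit leaves unreadable from compound 2 to compound 3. Compound 3 is therefore expected to give about 200000 nM in this assay, within 60000 nM to 600000 nM, most likely reported again only as a limit.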

Compound 3, half-maximal inhibitory concentration: > 128000 nM
Compound 3 ended at the assay's limit; the forecaster's own chance of this, stated with the estimate: 85%; the middle value lies beyond the limit too.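

No step can be read from compound 2 to compound 3 or from compound 1 to compound 3, because each of these compounds gives only a limit: the limit of > 128000 nM in this assay, at which 3 of the 3 values shown sit. As far as these compounds go, whether compound 1, compound 2 and compound 3 truly differ in this assay stays open.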